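The source may report more compounds than this note shows. Statements on the series, on what has been measured and on what is new or still open speak of the compounds shown alone.

Compound 2 `CC(C)C(Sc1nc2c(cnn2C)c(=O)n1-c1ccccc1)c1ccccc1` carries a branched thioether on the shared core, and in an assay on isolated protein for inhibition of aldehyde dehydrogenase 1A1 (Homo sapiens) (on this read-out higher numbers stand for weaker inhibition and lower numbers for stronger inhibition), compound 2 gives 380 nM. For the measured compounds named here, compound 1 `Cn1ncc2c(=O)n(-c3ccccc3)c(SC(C)(C)c3ccccc3)nc21` is the only other member measured so far; in this assay compound 1 gives 1900 nM. Of these two numbers compound 2 stands lowest, and its gap to compound 1 lies beyond the scatter. Compound 3 `CCC(Sc1nc2c(cnn2C)c(=O)n1-c1ccccc1)c1ccccc1` is the next member and awaits measurement in this assay. Relative to compound 2 the change is hydrogen in place of methyl on a saturated chain carbon bound to two saturated chain carbons, which shortens the branch from isopropyl to ethyl. Going by the values given here, no pair of measured compounds differing in a single place is available, so the size of such a step cannot be read directly from the series, and the comparison of compound 1 with compound 2 concerns a different alteration. In this assay a modest shift toward weaker inhibition is expected, a 1.4-fold higher number from compound 2 to compound 3 (0.16 log units; within the scatter), of a size that may or may not clear the scatter. Compound 3 is estimated at 550 nM, with a range from 200 nM to 1500 nM.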

Compound 3, half-maximal inhibitory concentration: 150 nM
Compound 3: the middle estimate sits 3.7-fold (0.56 log units) above what was measured, and the stated range ends above it.
By their numbers in this assay, from the lowest: compound 3; then compound 2; then compound 1.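

In this assay, the change from isopropyl to ethyl on the saturated chain carbon gives a 2.5-fold lower number from compound 2 to compound 3 (0.40 log units; beyond the scatter), so at this position the loss of one methyl strengthens inhibition, a direction that compound 1 and compound 2 alone could not show. The replacement on the sulfur of 1-methyl-1-phenylethyl by 1-phenylpropyl gives a 13-fold lower number from compound 1 to compound 3 (1.10 log units; beyond the scatter), which places compound 3 as the strongest of the three, with both of its steps beyond the scatter. No measurement in hand accounts for either step.

The series leaves open whether the trend continues to a methyl in place of the ethyl, or reverses with a longer chain such as n-propyl or n-butyl, since only the isopropyl and ethyl groups can be compared here. Also open, on these data alone, is how an amine or a carboxylic acid at the end of that chain would read in this assay, and whether a fluorine or methoxy group on the phenyl of the 1-phenylpropyl group would keep the strength of compound 3.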